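Mirror-image pair in a microsomal stability assay

The compounds below may be only part of what the source reports. "The series", "measured", "known", "first", "only" and "open" are said of these compounds alone.

Compound 1 `Cc1cc(C)c(CN2CCc3c(Cl)cc([C@H](CO)[C@H]4CCOC4)c(Cl)c3C2=O)c(=O)[nH]1`: 21.3 uL/min
Compound 2 `Cc1cc(C)c(CN2CCc3c(Cl)cc([C@H](CO)[C@H]4CCCO4)c(Cl)c3C2=O)c(=O)[nH]1`: 51.6 uL/min
Compound 3 `CCOC(c1cc(Cl)c2c(c1Cl)C(=O)N(Cc1c(C)cc(C)[nH]c1=O)CC2)C1CS(=O)(=O)C1`: 45.7 uL/min; 124 uL/min (2 entries)

These three compounds were tested in an ADME assay on microsomes from liver (Homo sapiens) for metabolic stability, read by LC-MS, using NADPH, with stated times of 10 min and 45 min, tested at 1 uM; a lower number here means slower removal, a higher number faster removal of the compound. For the measured compounds named here, compound 2 gives the highest of the two single numbers in this assay; its nearest neighbour is compound 1, and the step of a 2.4-fold higher number from compound 1 to compound 2 (0.38 log units; beyond the scatter) is the only measured step between compounds that differ in one place. Compound 3 has two entries rather than a single number, and the several entries of compound 3 in this assay, 45.7 uL/min; 124 uL/min (2 entries) shows how far repeated readings of one compound can lie apart in this assay.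

Compound 4 `Cc1cc(C)c(CN2CCc3c(Cl)cc([C@@H](CO)[C@@H]4CCCO4)c(Cl)c3C2=O)c(=O)[nH]1` has not yet been measured. It differs from compound 2 as follows: the two compounds have the same atoms and bonds and differ only in configuration as drawn: 2 of 2 stereo elements differ (all stereocentres are inverted: mirror images); a stereocentre at a saturated chain carbon is drawn R in compound 2 and S in compound 4; a stereocentre at a saturated ring carbon is drawn R in compound 2 and S in compound 4. Going by the values given here, no measured step shows how this assay responds to inversion of both stereocentres, so the measured steps give no guidance on direction here. The account therefore expects no step beyond the scatter, a 1.0-fold lower number from compound 2 to compound 4 (0.01 log units; within the scatter), and estimates compound 4 at 50 uL/min, within a range from 20 uL/min to 130 uL/min.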

Compound 4, intrinsic clearance in a liver preparation (reported as CLH), per the amount of preparation that the assay uses: 70.3 uL/min
Estimate against measurement, compound 4: 1.4-fold (0.15 log units) below; the range from low to high includes it.
By their numbers in this assay, from the lowest: compound 1; then compounds 2 and 4 (each within the scatter of the next).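

Inversion of both stereocentres, a change no earlier step covered, gives a 1.4-fold higher number from compound 2 to compound 4 (0.13 log units; within the scatter) in this assay, and that gap is no wider than the spread of repeated readings of a single compound: the several entries of compound 3 in this assay, 45.7 uL/min; 124 uL/min (2 entries). The step of a 3.3-fold higher number from compound 1 to compound 4 (0.52 log units; beyond the scatter) stands alongside a 2.4-fold higher number from compound 1 to compound 2 (0.38 log units; beyond the scatter), and both lie beyond the scatter, so the higher number seen with oxolan-2-yl in place of oxolan-3-yl holds for both mirror images.

The compounds shown leave open how this assay responds when only one of the two stereocentres is inverted, and whether the mirror image of compound 1 would match it. They also leave open how an oxan-4-yl ring, or an amine in place of the hydroxyl group, would read here.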